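Swapping halogens on a shared core against cancer cells

The source may report more compounds than this note shows. Statements on the series, on what has been measured and on what is new or still open speak of the compounds shown alone.

Compound 1 `O=C1c2cccc([N+](=O)[O-])c2NC[C@@]12[C@H](c1ccc(Br)cc1)[C@@H](c1ccccc1)N[C@]21C(=O)Nc2ccc(Cl)cc21` is the starting point. In a functional assay on HeLa cells (Homo sapiens) for cytotoxicity, read by MTT assay, with a stated time of 72 h (on this read-out lower numbers stand for stronger inhibition and higher numbers for weaker inhibition), compound 1 gives 21000 nM. Compound 2 `O=C1c2cccc([N+](=O)[O-])c2NC[C@@]12[C@H](c1ccc(F)cc1)[C@@H](c1ccccc1)N[C@]21C(=O)Nc2ccc(Cl)cc21` differs from it by fluoro in place of bromo on an aromatic carbon, and in this assay compound 2 gives 27000 nM, a step of a 1.3-fold higher number from compound 1 to compound 2 (0.11 log units; within the scatter). Compound 3 `O=C1c2cccc([N+](=O)[O-])c2NC[C@@]12[C@H](c1ccc(Br)cc1)[C@@H](c1ccccc1)N[C@]21C(=O)Nc2ccc(F)cc21` differs from compound 1 in the core by fluoro in place of chloro on an aromatic carbon; in this assay compound 3 gives 26000 nM, a step of a 1.2-fold higher number from compound 1 to compound 3 (0.09 log units; within the scatter). Compound 4 `O=C1c2cccc([N+](=O)[O-])c2NC[C@@]12[C@H](c1ccc(F)cc1)[C@@H](c1ccccc1)N[C@]21C(=O)Nc2ccc(F)cc21` has not been measured. It differs from compound 3 by fluoro in place of bromo on an aromatic carbon, the same change already seen between compound 1 and compound 2, at the same place. Because that earlier change gave a 1.3-fold higher number from compound 1 to compound 2 (0.11 log units; within the scatter), a similar small step is expected for compound 4, namely a 1.3-fold higher number from compound 3 to compound 4 (0.10 log units; within the scatter). Compound 4 is therefore estimated at 33000 nM, with a likely range from 18000 nM to 60000 nM.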

Compound 4, half-maximal inhibitory concentration: 20000 nM
Estimate against measurement, compound 4: 1.7-fold (0.22 log units) above; measured number inside the range.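

The swap from 4-bromophenyl to 4-fluorophenyl gives a 1.3-fold lower number from compound 3 to compound 4 (0.11 log units; within the scatter), which agrees with its earlier counterpart as far as this scatter can tell: the same change on two cores in this assay, a 1.3-fold higher number (0.11 log units; within the scatter) from compound 1 to compound 2 and a 1.3-fold lower number (0.11 log units; within the scatter) from compound 3 to compound 4, 1.7-fold (0.22 log units) apart, within the scatter of two such steps. The swap of chloro to fluoro gives a 1.4-fold lower number from compound 2 to compound 4 (0.13 log units; within the scatter), and it agrees in the same way: the same change on two cores in this assay, a 1.2-fold higher number (0.09 log units; within the scatter) from compound 1 to compound 3 and a 1.4-fold lower number (0.13 log units; within the scatter) from compound 2 to compound 4, 1.7-fold (0.22 log units) apart, within the scatter of two such steps. In this assay, this shows that neither swap gives a step beyond the scatter on either core, but it does not show that a real effect carries from one core to another, since steps this small cannot reveal one, and their opposite directions carry no meaning.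

The compounds shown hold only halogens at these two places. Going by these compounds, an amine or a carboxylic acid there remains open, as does whether a larger step would carry across cores.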